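A fluoro swap within a narrow set of values

The source may report more compounds than this note shows. Statements on the series, on what has been measured and on what is new or still open speak of the compounds shown alone.

- compound 1 `COc1cc2ccc(CCc3ccc4ccccc4c3)cc2cc1O` gives 3590 nM
- compound 2 `COCCOc1cc(/C=C\c2ccc3ccccc3c2)ccc1OC` gives 2990 nM
- compound 3 `COc1cccc(/C=C\c2ccc3ccccc3c2)c1` gives 1920 nM

In a functional assay on SK-MEL-28 cells (Homo sapiens) for inhibition (on this read-out lower numbers stand for stronger inhibition and higher numbers for weaker inhibition), the three measured compounds lie close together. Compound 3 gives 1920 nM and its gaps to compound 1 and to compound 2 both stay within the usual scatter, so the numbers set no order among the three. Within the data shown here, no measured pair differs in only one place, so no single change has a measured size here.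

Compound 4 `COc1cc(/C=C\c2ccc3ccccc3c2)ccc1F` comes from compound 3 by one change: fluoro in place of hydrogen on an aromatic carbon with fluoro in place of hydrogen on an aromatic carbon, ortho to a methoxy group and para to a large group. The expectation rests on compound 2 at 2990 nM and compound 1 at 3590 nM staying within the scatter of compound 3 while differing from it in more than one place. The expected result is a 1.0-fold lower number from compound 3 to compound 4 (0.00 log units; within the scatter) with no step beyond the scatter in either direction. For compound 4 the estimated value is 1900 nM with an expected range from 800 nM to 4500 nM in this assay.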

Compound 4, half-maximal inhibitory concentration: 450 nM
Compound 4: the middle estimate sits 4.2-fold (0.63 log units) above what was measured, outside the stated range (below it).
By their numbers in this assay, from the lowest: compound 4; then compounds 3, 2 and 1 (each within the scatter of the next).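

In this assay, among these compounds, fluoro in place of hydrogen on an aromatic carbon gives a 4.3-fold lower number from compound 3 to compound 4 (0.63 log units; beyond the scatter), the first single change in this set with a measured size. Among the compounds shown here, it shows that this position, ortho to a methoxy group and para to a large group, responds to a single added fluorine atom, which the earlier compounds could not show, as each differs from the others in more than one place. Nothing shown accounts for the step.

Going by these compounds, only fluoro stands at this position, so it remains open whether a chlorine atom, a methyl group or a nitrile there would give a similar number. On these data alone, it also remains open whether the same swap would give a step of this kind on compound 1 or compound 2.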